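One Stereocentre Redrawn in a Pair of Close Relatives

The source may hold more compounds than are shown below. What is called first, only, known or untested is meant among the compounds shown, and "the series" means these compounds.

In a functional assay on HeLa cells (Homo sapiens) for antiproliferative activity, with a stated time of 48 h (on this read-out lower numbers stand for stronger inhibition and higher numbers for weaker inhibition), compound 1 `Cc1cc(=O)c2c(O)cc(OC[C@H]3CO3)cc2o1` gives 16700 nM and compound 2 `Cc1cc(=O)c2c(OC[C@@H]3CO3)cc(OC[C@@H]3CO3)cc2o1` gives 21700 nM. Among the compounds with values here, these two numbers lie within the usual scatter of each other, so compound 2 stands level with the only other measured compound.

Compound 3 `Cc1cc(=O)c2c(OC[C@@H]3CO3)cc(OC[C@H]3CO3)cc2o1` is a very close relative of compound 2 (the two compounds have the same atoms and bonds and differ only in configuration as drawn: 1 of 2 stereo elements differ; a stereocentre at a saturated ring carbon is drawn S in compound 2 and R in compound 3). The two compounds have the same atoms and bonds and differ only in configuration as drawn: a stereocentre at a saturated ring carbon is drawn S in compound 2 and R in compound 3.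

Within the data shown here, no measured pair here shows what a change of this kind does, so the data give no direct guide to its size or direction. Changes in configuration can matter in cells, but nothing here says that this one does. Starting from compound 2 at 21700 nM, the expectation in this assay is no shift beyond the scatter, in either direction. The expected change, a 1.1-fold lower number from compound 2 to compound 3 (0.04 log units; within the scatter), is therefore small. For compound 3 the estimated value is 20000 nM, with an expected range from 10000 nM to 40000 nM.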

Compound 3, half-maximal inhibitory concentration: 11000 nM
Beside the measured number, compound 3's estimate is 1.8-fold (0.26 log units) above it; the measured number falls inside the stated range.
By their numbers in this assay, from the lowest: compounds 3, 1 and 2 (each within the scatter of the next).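

Within the data shown here, the step from S to R at this saturated ring carbon is the first reading of a change in configuration alone, and it can be read cleanly because nothing else separates the two structures: the fact that compounds 2 and 3 differ only in the configuration as drawn. In this assay, that change gives a 2.0-fold lower number from compound 2 to compound 3 (0.30 log units; within the scatter), so redrawing this one stereocentre leaves the result within the usual variation between repeat measurements, and these data give no sign that this configuration matters. The other step, with (oxiran-2-yl)methyl in place of hydrogen on an oxygen on an aromatic ring, gives a 1.5-fold lower number from compound 1 to compound 3 (0.18 log units; within the scatter), so adding this group to the core of compound 1 also stays within that variation.

The compounds shown leave open whether redrawing the other stereocentre, alone or together with this one, would give a result beyond the scatter. They also leave open whether a different group in place of (oxiran-2-yl)methyl, such as an amine, a carboxylic acid or a longer chain, would shift the number by more than any step seen here.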